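The source may hold more compounds than are shown below. What is called first, only, known or untested is meant among the compounds shown, and "the series" means these compounds.

In a functional assay on U-251 cells (Homo sapiens) for cytotoxicity (on this read-out lower numbers stand for stronger inhibition of growth and higher numbers for weaker inhibition of growth), compound 2 `COc1ccc(C2=C(c3ccc(SC)cc3)CC3CCCN3C2=O)cc1O` gives 5000 nM. That is the higher of the two true numbers in this small set. In compound 3 `COc1ccc(C2=C(c3ccc(SC)cc3)CC3CCCN3C2=O)cc1OC(=O)C1CCCN1C(=O)OC(C)(C)C` the hydroxy of compound 2 is capped as an ester, and compound 3 gives 2000 nM, a gap beyond the usual scatter. Compound 1 `COc1ccc(C2=C(c3cc(OC)c(OC)c(OC)c3)CC3CCCN3C2=O)cc1O` shows > 100000 nM, which is a limit of the assay and not a number.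

The next step leads to compound 4 `COc1ccc(C2=C(c3ccc(SC)cc3)CC3CCCN3C2=O)cc1Br`, with the change bromo in place of hydroxy on an aromatic carbon, ortho to a methoxy group, turning 3-hydroxy-4-methoxyphenyl into 3-bromo-4-methoxyphenyl. Among the measured compounds shown here, no measured pair isolates this swap. The nearest guide is compound 3, which has no free hydroxy and still reads 2000 nM, so losing that hydroxy need not weaken growth inhibition. This is one comparison with a very different group, so only a modest gain is expected. The expected change is a 2.5-fold lower number from compound 2 to compound 4 (0.40 log units; beyond the scatter), toward stronger inhibition of growth. For compound 4 the estimated value is 2000 nM, with an expected range of 400 nM to 10000 nM.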

Compound 4, concentration for 50% growth inhibition: 800 nM
Beside the measured number, compound 4's estimate is 2.5-fold (0.40 log units) above it; low and high end bracket the measured number.
By their numbers in this assay, from the lowest: compound 4; then compound 3; then compound 2. At a limit, above all of these: compound 1.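

In this assay, the free hydroxy on this aromatic carbon proves not to be needed for growth inhibition in this series: replacing it with bromo gives a 6.3-fold lower number from compound 2 to compound 4 (0.80 log units; beyond the scatter). Compound 3 had capped that hydroxy but kept an oxygen at this place, whereas compound 4 has no oxygen there and, at 800 nM, gives the lowest number of the set. Nothing measured here explains the gain.

The compounds shown leave open whether the gain is particular to bromo or would also appear with chloro, methyl or an amine on the same carbon. They also leave open whether the same swap would carry over to compound 1, whose > 100000 nM is a limit of the assay and not a number.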